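This account rests on a few compounds, and the source may have more. Where it says the series, first, only, none or still open, it means among the compounds named here.

Measured in an assay for inhibition of acyl-CoA (8-3)-desaturase (Homo sapiens); on this read-out higher numbers stand for weaker inhibition and lower numbers for stronger inhibition:

Compound 1 `Clc1cccc(Nc2cccc3ccccc23)c1` gives 17 nM
Compound 2 `Clc1cccc(Nc2nccc3occc23)c1` gives 371 nM
Compound 3 `Clc1cccc(Nc2n[nH]c3ccccc23)c1` gives 84 nM

Among these three, compound 3 holds the middle position: its number lies between that of compound 1, which is lower, and that of compound 2, which is higher, and both of those gaps are beyond the usual scatter. Compound 4 `COc1ccc2[nH]nc(Nc3cccc(Cl)c3)c2c1` is built from compound 3 by one change, (methoxy in place of hydrogen on an aromatic carbon). Among the measured compounds shown here, no measured pair shows what this change does on this assay, so nothing here points to a large shift in either direction; the step from compound 3 to compound 4 is expected to stay close to the scatter, a 1.2-fold lower number from compound 3 to compound 4 (0.08 log units; within the scatter). Compound 4 is therefore estimated at 70 nM, with a plausible range from 20 nM to 250 nM.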

Compound 4, half-maximal inhibitory concentration: 8 nM
Compound 4: middle estimate off by 8.8-fold (0.94 log units), on the high side; the measured number lies below the stated range.
By their numbers in this assay, from the lowest: compound 4; then compound 1; then compound 3; then compound 2.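

In this assay, putting methoxy in place of hydrogen on the six-membered carbon-only ring gives an 11-fold lower number from compound 3 to compound 4 (1.02 log units; beyond the scatter), a step well beyond the scatter. This position is therefore sensitive to substitution, and a group of only 2 heavy atoms can change the number substantially. Nothing available here explains why the step is so large.

On these data alone, whether a hydroxyl, an amine or a longer ethoxy chain at this position would give a similar step remains open. It is also unknown whether methoxy would have a similar effect on the cores of compound 1 or compound 2.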